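Trifluoromethyl in place of fluoro on an aromatic carbon

The source may hold more compounds than are shown below. What is called first, only, known or untested is meant among the compounds shown, and "the series" means these compounds.

Compound 1 `Nc1ccc(NC(=O)CCCCCCC(=O)NO)cc1`: 8500 nM
Compound 2 `O=C(CCCCCCC(=O)Nc1cccc(F)c1)NO`: 1900 nM

Going by the values given here, in a functional assay on SK-BR-3 cells (Homo sapiens) for antiproliferative activity, with a stated time of 48 h (a higher number here means that more compound is needed for the effect, a lower number that less compound is needed), compound 2 gives 1900 nM, the lower of the two numbers so far. Compound 1 stands higher at 8500 nM, and that gap lies beyond the usual scatter. Compound 3 `O=C(CCCCCCC(=O)Nc1cccc(C(F)(F)F)c1)NO` is the next to be tested. It carries trifluoromethyl in place of fluoro on an aromatic carbon, meta to a large group: trifluoromethyl in place of fluoro on an aromatic carbon. Among the compounds with values here, no two measured compounds differ in one place only, so the data hold no direct precedent for this change. In this assay the expectation is no step beyond the scatter, in either direction. The expected change is a 1.1-fold higher number from compound 2 to compound 3 (0.02 log units; within the scatter). For compound 3 the estimated value is 2000 nM, with an expected range from 800 nM to 5000 nM.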

Compound 3, half-maximal effective concentration: 26000 nM
Beside the measured number, compound 3's estimate is 13-fold (1.11 log units) below it, outside the stated range (above it).
By their numbers in this assay, from the lowest: compound 2; then compound 1; then compound 3.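

In this assay, trifluoromethyl in place of fluoro on an aromatic carbon, meta to a large group, brings a 14-fold higher number from compound 2 to compound 3 (1.14 log units; beyond the scatter). This is the first one-place comparison among the compounds shown, and it shows that the number at this position is sensitive to the group placed there: the change from 1 heavy atom to 4 moves it beyond the scatter, although neither group has a hydrogen-bond donor, a hydrogen-bond acceptor or a net charge. Nothing in the data shown explains why the step is this large.

Going by these compounds, what a chlorine atom, a methyl group or a methoxy group on that same aromatic carbon would give remains open. Also open, on these data alone, is whether the same change would bring a step of this size at another place on the ring.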